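This account rests on a few compounds, and the source may have more. Where it says the series, first, only, none or still open, it means among the compounds named here.

This piece follows a single change from compound 2, whose structure is `O=S(=O)(NCCNC(=S)Nc1ccc(Cl)cc1)c1ccc(-c2ccccc2OCc2ccccc2)s1`, to compound 4, whose structure is `O=[N+]([O-])c1ccc(NC(=S)NCCNS(=O)(=O)c2ccc(-c3ccccc3OCc3ccccc3)s2)cc1`. Of the compounds shown here, three have so far been tested in a functional assay on HL-60 cells (Homo sapiens) for inhibition, read by CCK-8 assay, with a stated time of 48 h; a higher number here means a weaker inhibitor, a lower number a stronger inhibitor. In this assay compound 2 gives only a limit of the assay, > 50000 nM, and no number. Compound 1, `COc1ccc(Oc2ccccc2-c2ccsc2S(=O)(=O)N2CCN(C(=O)Nc3ccc([N+](=O)[O-])cc3)CC2)cc1OC`, likewise gives only a limit in this assay, > 50000 nM. Compound 3, `COc1ccc(Oc2ccc([N+](=O)[O-])cc2-c2ccsc2S(=O)(=O)N2CCN(C(=S)Nc3ccc([N+](=O)[O-])cc3)CC2)cc1OC`, also reaches only a limit in this assay, > 50000 nM. So compound 2 stands where every measured compound stands, at the limit of > 50000 nM in this assay, at which 3 of the 3 values shown sit, with no number that would rank it against the others.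

The change from compound 2 to compound 4 is nitro in place of chloro on an aromatic carbon. It sits on an aromatic carbon of a six-membered aromatic ring of carbon only, para to a large group. Within the data shown here, no step between two measured compounds is available to say what such a change does here. Because the limit of > 50000 nM in this assay, at which 3 of the 3 values shown sit, already holds all three measured compounds, the expected step is none beyond the scatter: a step that the limit leaves unreadable from compound 2 to compound 4 in this assay. Compound 4 is expected to give 60000 nM, between 20000 nM and 200000 nM, most likely again as a limit only.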

Compound 4, half-maximal inhibitory concentration: > 50000 nM
Compound 4 gave a limit, no number (the forecaster's own chance of this, stated with the estimate: 80%); the middle value does not contradict the limit.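

No step from compound 2 to compound 4 can be read in this assay, because both give only a limit and not a number: the limit of > 50000 nM in this assay, at which 4 of the 4 values shown sit.

The compounds shown leave open whether nitro in place of chloro changes inhibition at all, as none of them gives a number.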